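Series notes: pyrazole amides at the cold-menthol channel

The source may hold more compounds than are shown below. What is called first, only, known or untested is meant among the compounds shown, and "the series" means these compounds.

Measured compounds:
- compound 1, `Cc1ccc(OCC(=O)N(Cc2cccs2)c2c[nH]nc2C)cc1`: 0.4 nM
- compound 2, `O=C(COc1ccc2c(c1)CCC2)N(Cc1cccs1)c1ccn[nH]1`: 0.001 nM

In an assay on HEK293 cells for agonist activity at transient receptor potential cation channel subfamily M member 8 (Homo sapiens), read by fluorescence and calcium flux, with a stated time of 15 min (on this read-out higher numbers stand for an effect only at larger amounts of compound and lower numbers for an effect already at smaller amounts), compound 1 gives 0.4 nM. Among the compounds with values here, it stands highest of the two numbers so far; its nearest neighbour, compound 2, gives 0.001 nM, a lower number, and the gap between the two is beyond the scatter. Within the data shown here, no pair of measured compounds differs in one place only, so no step can be read off, and compound 1 and compound 2 differ in more than one part of the structure.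

Compound 3, `Cc1ccc(OCC(=O)N(Cc2cccs2)c2ccnn2C)cc1`, is not yet measured. It differs from compound 1 as follows: 1-methyl-1H-pyrazol-5-yl in place of 3-methyl-1H-pyrazol-4-yl on an amide-type nitrogen. The two have the same atoms, joined differently; a hydrogen-bond donor leaves and a hydrogen-bond acceptor enters on the amide-type nitrogen. No measured comparison tells what this change does. The expected step is a 5.0-fold higher number from compound 1 to compound 3 (0.70 log units; beyond the scatter), a moderate move toward higher numbers. For compound 3 the estimate is 2 nM, within 0.3 nM to 15 nM.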

Compound 3, half-maximal effective concentration: 422 nM
Estimate against measurement, compound 3: 210-fold (2.32 log units) below; measured number outside the range, above it.
By their numbers in this assay, from the lowest: compound 2; then compound 1; then compound 3.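

In this assay, within the data shown here, 1-methyl-1H-pyrazol-5-yl in place of 3-methyl-1H-pyrazol-4-yl on the amide-type nitrogen gives a 1100-fold higher number from compound 1 to compound 3 (3.02 log units; beyond the scatter), the only step that can be read so far. The two compounds have the same atoms, joined differently, so this position responds to the arrangement of the pyrazole and not only to its atom content. The hydrogen-bond donor count falls from 1 to 0 with this change, but no supporting data explain the size of the step.

The compounds shown leave open whether the step follows the methyl on a ring nitrogen or the changed point of attachment, a question that a 1-methyl-1H-pyrazol-4-yl group on the same nitrogen would address. Also open, going by these compounds, is how an ethyl group in place of that methyl would read.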